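The source may hold more compounds than are shown below. What is called first, only, known or untested is meant among the compounds shown, and "the series" means these compounds.

Compounds measured so far:
- compound 1 `CCC1CCCCN1c1nc(C)nc2c(-c3c(C)cc(OC)cc3OC)c(C)nn12`: 3.26 nM
- compound 2 `COc1ccc(-c2c(C)nn3c(N4CCCC4)nc(C)nc23)c(C)c1`: 80.7 nM
- compound 3 `CCC(CC)Nc1nc(C)nc2c(-c3ccc(OC)cc3)c(C)nn12`: 3.8 nM

In an assay on cell membranes for displacement of a labelled ligand from corticotropin-releasing factor receptor 1 (Rattus norvegicus) (a lower number here means a stronger inhibitor, a higher number a weaker inhibitor), compound 1 has the lowest number of the three. Compound 3 sits so close that the two cannot be told apart within the usual scatter, so neither can be called the stronger. Compound 2 lies well above both, a gap that is clearly beyond the scatter.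

Compound 4 `C=CCN(CC=C)c1nc(C)nc2c(-c3c(C)cc(OC)cc3OC)c(C)nn12` carries one change relative to compound 1: diallylamino in place of 2-ethylpiperidin-1-yl on an aromatic carbon. Among the compounds with values here, no measured pair shows this exact swap, so the expectation rests on the fact that compound 3, with an acyclic amine on the shared core, gives 3.8 nM. From this, a step from compound 1 to compound 4 of a 1.5-fold higher number from compound 1 to compound 4 (0.19 log units; within the scatter) is estimated, essentially none beyond the scatter. Compound 4 is therefore expected near 5 nM, ranging from 1.5 nM to 16 nM.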

Compound 4, half-maximal inhibitory concentration: 1 nM
Compound 4: middle estimate off by 5.0-fold (0.70 log units), on the high side, outside the stated range (below it).
By their numbers in this assay, from the lowest: compound 4; then compounds 1 and 3 (each within the scatter of the next); then compound 2.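

Replacing 2-ethylpiperidin-1-yl with diallylamino on this aromatic carbon gives, in this assay, a 3.3-fold lower number from compound 1 to compound 4 (0.51 log units; beyond the scatter). On the core of compound 1, then, this position accepts an amine with no ring and two double bonds, and the number improves rather than worsens. Nothing available explains this gain.

The compounds shown leave open whether the ring's removal or the two double bonds account for the step. A dipropylamino group at this position would help separate those two changes.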